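Compound 3 to compound 4: exchange of one aryl group

The source may hold more compounds than are shown below. What is called first, only, known or untested is meant among the compounds shown, and "the series" means these compounds.

Among the measured compounds shown here, in a functional assay on DU-145 cells (Homo sapiens) for cytotoxicity (a lower number here means a stronger inhibitor of growth, a higher number a weaker inhibitor of growth), compound 3 `COc1ccc(C2=C(c3ccc(SC)cc3)CC3CCCN3C2=O)cc1Br` gives 900 nM, the lower of the two actual numbers so far. Compound 2 `COc1ccc(C2=C(c3ccc(SC)cc3)CC3CCCN3C2=O)cc1OC(=O)CNC(=O)OC(C)(C)C` gives 10000 nM. Compound 1 `COc1ccc(C2=C(c3cc(OC)c(OC)c(OC)c3)CC3CCCN3C2=O)cc1O` gives > 100000 nM, which is a limit of the assay and not a number.

Next in line is compound 4 `CSc1ccc(C2=C(c3ccc(F)c(F)c3)C(=O)N3CCCC3C2)cc1`, which keeps the 4-(methylsulfanyl)phenyl group and carries 3,4-difluorophenyl in place of 3-bromo-4-methoxyphenyl on a double-bonded ring carbon.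

For the measured compounds named here, one measured step bears on this change: an 11-fold lower number from compound 2 to compound 3 (1.05 log units; beyond the scatter). That large step falls on the same aryl group that is exchanged here, so changes on this group can clearly move the number in this assay. It is only indirect evidence, since all three measured compounds keep the methoxy group and none carries fluorine. Compound 3 holds the lowest number at 900 nM, so a rise is judged more likely than a fall, though the direction remains uncertain. The expected change is a 4.4-fold higher number from compound 3 to compound 4 (0.65 log units; beyond the scatter), a step beyond the scatter towards weaker inhibition of growth. For compound 4 the estimated value is 4000 nM, with an expected range of 800 nM to 25000 nM.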

Compound 4, concentration for 50% growth inhibition: 500 nM
Beside the measured number, compound 4's estimate is 8.0-fold (0.90 log units) above it, and the stated range ends above it.
By their numbers in this assay, from the lowest: compounds 4 and 3 (each within the scatter of the next); then compound 2. At a limit, above all of these: compound 1.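

Working notes on this aryl position: a 1.8-fold lower number from compound 3 to compound 4 (0.26 log units; within the scatter). In this assay, 3,4-difluorophenyl therefore stands level with 3-bromo-4-methoxyphenyl, so this pair shows that the methoxy group and the bromine, both kept in compound 3, are not required at this double-bonded ring carbon for a number at this level, and that a group with no hydrogen-bond acceptor serves as well here as one with an acceptor. Among the compounds shown here, the earlier step on this aryl group showed only that the number can move a long way, whereas this pair shows that two quite different substituted phenyl groups can give the same level while the 4-(methylsulfanyl)phenyl group stays in place. Nothing available explains why these two aryl groups give matching numbers, and a single pair within the scatter gives no ranking of fluorine against bromine or methoxy.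

Going by these compounds, whether an unsubstituted phenyl, or a phenyl carrying an amine or a carboxylic acid, would hold this level remains open. Also open, on these data alone, is whether the 4-(methylsulfanyl)phenyl group can itself be exchanged while 3,4-difluorophenyl stays in place, for instance for a phenyl bearing a nitrile.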